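Shortening the fluoroalkoxy chain on compound 2

The source may report more compounds than this note shows. Statements on the series, on what has been measured and on what is new or still open speak of the compounds shown alone.

Within the data shown here, compound 2 `FCCCOc1cccc(-c2cn([C@@H]3CN4CCC3CC4)nn2)c1` stands at the higher of the two numbers measured so far in an assay on HEK293 cells for displacement of a labelled ligand from Neuronal acetylcholine receptor; alpha3/beta4 (Homo sapiens), read by scintillation counting, with a stated time of 120 min; a lower number here means a stronger inhibitor, a higher number a weaker inhibitor: compound 2 gives 19.5 nM, while compound 1 `Fc1cccc(-c2cn([C@@H]3CN4CCC3CC4)nn2)c1` gives 2.25 nM. Among the measured compounds shown here, the single measured step, an 8.7-fold higher number from compound 1 to compound 2 (0.94 log units; beyond the scatter), comes from putting 3-fluoropropoxy in place of fluoro on the aromatic carbon. Compound 3 `FCCOc1cccc(-c2cn([C@@H]3CN4CCC3CC4)nn2)c1` has not yet been measured; it differs from compound 2 by fluoro in place of fluoromethyl on a saturated chain carbon, two bonds along the chain from an oxygen on an aromatic ring, so the 3-fluoropropoxy chain becomes 2-fluoroethoxy while the oxygen on the ring remains. For the measured compounds named here, no measured step repeats exactly this change; the only one that bears on it is an 8.7-fold higher number from compound 1 to compound 2 (0.94 log units; beyond the scatter), which covers the whole chain rather than one unit of it. Because that step was an 8.7-fold higher number from compound 1 to compound 2 (0.94 log units; beyond the scatter), compound 3 is expected to move toward compound 1 by the smaller step of a 2.0-fold lower number from compound 2 to compound 3 (0.29 log units; within the scatter). Compound 3 is therefore estimated at 10 nM, within 4 nM to 30 nM.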

Compound 3, inhibition constant: 11.8 nM
Estimate against measurement, compound 3: 1.2-fold (0.07 log units) below; low and high end bracket the measured number.
By their numbers in this assay, from the lowest: compound 1; then compounds 3 and 2 (each within the scatter of the next).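

In this assay the shorter chain shows that this position tolerates the change: on a saturated chain carbon, two bonds along the chain from an oxygen on an aromatic ring, fluoro in place of fluoromethyl gives a 1.7-fold lower number from compound 2 to compound 3 (0.22 log units; within the scatter) and so leaves 3-fluoropropoxy and 2-fluoroethoxy not told apart. On these data alone, the gap to the plain fluoro compound stays open with the shorter chain, at a 5.2-fold higher number from compound 1 to compound 3 (0.72 log units; beyond the scatter) and so beyond the scatter, which means that this shortening does not bring the number back to that of compound 1. Nothing measured here bears on the reason for either step.

Still open, as far as these compounds go, is whether fluoromethoxy, or methoxy or ethoxy without any fluorine, would stand nearer compound 1. Also open, from the compounds shown here alone, is whether a longer chain such as 4-fluorobutoxy would stay within the scatter of compound 2.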